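Replacing a methoxyphenyl with a methylphenyl on one core

The compounds below may be only part of what the source reports. "The series", "measured", "known", "first", "only" and "open" are said of these compounds alone.

Compound 1 `CCOC(=O)c1c(-c2ccc(OC)cc2)[nH]c2cccc(OC)c2c1=O` and compound 2 `CCOC(=O)c1c(-c2ccc(Cl)cc2)[nH]c2cc(OC)ccc2c1=O` share a core and were both tested in a physicochemical assay for solubility, in phosphate buffer, at pH 7.4; a lower number here means a less soluble compound, a higher number a more soluble compound. For compound 1 the result is only a limit of the assay, > 100000 nM, not a number. In this assay compound 2 gives 3000 nM. Compound 3 `CCOC(=O)c1c(-c2ccccc2C)[nH]c2cccc(OC)c2c1=O` has not yet been measured. It differs from compound 1 in one place: 2-methylphenyl in place of 4-methoxyphenyl on an aromatic carbon. For the measured compounds named here, compound 1 sits at the limit (the limit of > 100000 nM in this assay, at which 1 of the 2 values shown sits), so no measured step anchors this change. The account expects compound 3 to turn out less soluble, with an at least 3.3-fold lower number from compound 1 to compound 3 (0.52 log units; beyond the scatter) as a moderate drop. Compound 3 is estimated at 30000 nM, within 5000 nM to 150000 nM.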

Compound 3, solubility: > 100000 nM
Compound 3 ended at the assay's limit (the forecaster's own chance of this, stated with the estimate: 35%); at least 3.3-fold (0.52 log units) between middle value and limit.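

No step from compound 1 to compound 3 can be read in this assay, as both compounds stand at a limit and give no number: the limit of > 100000 nM in this assay, at which 2 of the 3 values shown sit.

Going by these compounds, how far 2-methylphenyl in place of 4-methoxyphenyl moves the read-out in this assay stays open.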